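The source may report more compounds than this note shows. Statements on the series, on what has been measured and on what is new or still open speak of the compounds shown alone.

Measured so far, in an assay on HEK293 cells for displacement of a labelled ligand from Melanocortin receptor 4 (Homo sapiens); a higher number here means a weaker inhibitor, a lower number a stronger inhibitor:

- compound 1 `CC(C)C[C@H](N)c1cc(C(F)(F)F)ccc1N1CCN(C(=O)CCc2ccccc2Cl)CC1`: 1700 nM
- compound 2 `COc1ccc(CCC(=O)N2CCN(c3ccc(C(F)(F)F)cc3[C@@H](N)CC(C)C)CC2)cc1`: 350 nM

Compound 2 holds the lower of the two numbers in this assay, the step of a 4.9-fold lower number from compound 1 to compound 2 (0.69 log units; beyond the scatter) separating it from compound 1. Within the data shown here, that is the only measured step, and it concerns the aryl group on the chain attached to the amide carbonyl.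

Compound 3 `CC(C)C[C@H](N)c1cc(C(F)(F)F)ccc1N1CCN(C(=O)CCc2c[nH]c3ccccc23)CC1` differs from compound 2 at the same place: 1H-indol-3-yl in place of 4-methoxyphenyl on a saturated chain carbon, two bonds along the chain from a carbonyl carbon. Among the measured compounds shown here, no measured pair covers an exchange of this kind; the single available step shows only that the aryl group at this position moves the number by a modest amount. For the measured compounds named here, the change to compound 3 has no direct precedent, so the expected step of a 1.1-fold higher number from compound 2 to compound 3 (0.06 log units; within the scatter) is set at about none beyond the scatter, with the uncertainty widened to allow for a shift of the size already seen. Compound 3 is therefore estimated at 400 nM in this assay, within a range from 120 nM to 1300 nM.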

Compound 3, inhibition constant: 640 nM
Compound 3: the middle estimate sits 1.6-fold (0.20 log units) below what was measured, within the range that was stated.
By their numbers in this assay, from the lowest: compounds 2 and 3 (each within the scatter of the next); then compound 1.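

Replacing 4-methoxyphenyl with 1H-indol-3-yl gives a 1.8-fold higher number from compound 2 to compound 3 (0.26 log units; within the scatter) in this assay, so this position accepts a two-ring aryl group with a hydrogen-bond donor and no hydrogen-bond acceptor as readily as a single ring with an acceptor and no donor. Against 2-chlorophenyl, the same group gives a 2.7-fold lower number from compound 1 to compound 3 (0.42 log units; beyond the scatter) and so both exchanges at this position now separate compound 1 from the other two compounds. No measurement available here accounts for these steps.

The compounds shown leave open whether the gap to compound 1 follows from the presence of the chlorine or from the other features of that ring, which a plain phenyl group on the same chain would help to settle. As far as these compounds go, a pyridine ring or a longer chain between the carbonyl and the aryl group also remains open.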